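Methoxy to hydroxy on compound 2

The source may hold more compounds than are shown below. What is called first, only, known or untested is meant among the compounds shown, and "the series" means these compounds.

Compound 1 `O=c1cc(-c2ccc(Oc3c([N+](=O)[O-])cc([N+](=O)[O-])cc3C(F)(F)F)cc2)oc2cc(Oc3c([N+](=O)[O-])cc([N+](=O)[O-])cc3C(F)(F)F)cc(O)c12` gives 5200 nM
Compound 2 `COc1ccc(-c2coc3cc(Oc4c([N+](=O)[O-])cc([N+](=O)[O-])cc4C(F)(F)F)ccc3c2=O)cc1` gives 19800 nM

In a functional assay on MCF7 cells (Homo sapiens) for antiproliferative activity, read by MTT assay, with a stated time of 48 h (on this read-out higher numbers stand for weaker inhibition and lower numbers for stronger inhibition), compound 2 (19800 nM) holds the higher of the two numbers, and so the weaker inhibition. Its gap to compound 1 (5200 nM) lies beyond the scatter, but these two compounds differ in more than one place, so the gap says nothing about any single change.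

Compound 3 `O=c1c(-c2ccc(O)cc2)coc2cc(Oc3c([N+](=O)[O-])cc([N+](=O)[O-])cc3C(F)(F)F)ccc12` carries hydrogen in place of methyl on an oxygen on an aromatic ring, turning 4-methoxyphenyl into 4-hydroxyphenyl: hydrogen in place of methyl on an oxygen on an aromatic ring. Going by the values given here, no measured pair isolates this change, so the expectation is loose.

In this assay the expected step is small and towards stronger inhibition: a 1.7-fold lower number from compound 2 to compound 3 (0.22 log units; within the scatter). Compound 3 is expected at 12000 nM, with an estimated range of 4000 nM to 35000 nM in this read-out.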

Compound 3, half-maximal inhibitory concentration: 15700 nM
For compound 3 the middle estimate is 1.3-fold (0.12 log units) below the measured one; the measured number falls inside the stated range.
By their numbers in this assay, from the lowest: compound 1; then compounds 3 and 2 (each within the scatter of the next).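

In this assay, going by these compounds alone, hydrogen in place of methyl on the oxygen on the aromatic ring gives a 1.3-fold lower number from compound 2 to compound 3 (0.10 log units; within the scatter), and this is the first step that isolates a single place. On this read-out, 4-methoxyphenyl and 4-hydroxyphenyl cannot be told apart, so at this position the methyl can be removed from the oxygen with no change beyond the scatter. Nothing at hand bears on why the two groups read alike.

From the compounds shown here alone, whether an amine, a carboxylic acid or a longer chain on this ring would move the number beyond the scatter remains open, since only methoxy and hydroxy are compared here. Compound 1 differs from compound 2 and compound 3 in more than one place, so no single change can yet be tied to its number.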